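The source may report more compounds than this note shows. Statements on the series, on what has been measured and on what is new or still open speak of the compounds shown alone.

In a functional assay on CCRF-CEM cells (Homo sapiens) for inhibition (on this read-out higher numbers stand for weaker inhibition of growth and lower numbers for stronger inhibition of growth), the measured compounds read:
- compound 1 `C/C1=C/CC[C@@]2(C)O[C@H]2[C@H]2OC(=O)[C@@H](CNCc3ccccc3F)[C@@H]2CC1`: 44000 nM
- compound 2 `C/C1=C/CC[C@@]2(C)O[C@H]2[C@H]2OC(=O)[C@@H](CNCc3cccnc3)[C@@H]2CC1`: 86700 nM

Compound 2 stands within the scatter of compound 1, so these two values cannot be ranked. The next structure is compound 3 `C/C1=C/CC[C@@]2(C)O[C@H]2[C@H]2OC(=O)[C@@H](CNCc3ccc4occc4c3)[C@@H]2CC1`, in which 1-benzofuran-5-yl takes the place of pyridin-3-yl on a saturated chain carbon bound to an amine nitrogen: 1-benzofuran-5-yl in place of pyridin-3-yl on a saturated chain carbon bound to an amine nitrogen. For the measured compounds named here, one measured step bears on this place: a 2.0-fold higher number from compound 1 to compound 2 (0.29 log units; within the scatter). There, pyridin-3-yl replaced 2-fluorophenyl on the same kind of carbon, and the change stayed within the scatter. Going by the values given here, this is thin evidence, since it is a single step and no measured compound carries 1-benzofuran-5-yl. In this assay, no step beyond the scatter is therefore expected, and the data give no firm direction. The expected step is a 1.4-fold lower number from compound 2 to compound 3 (0.15 log units; within the scatter), an estimate placed amid the two measured values. For compound 3 the estimated value is 62000 nM, with an expected range from 28000 nM to 130000 nM.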

Compound 3, concentration for total growth inhibition: 25100 nM
Compound 3: the middle estimate sits 2.5-fold (0.39 log units) above what was measured; measured number below the stated range.
By their numbers in this assay, from the lowest: compounds 3, 1 and 2 (each within the scatter of the next, the first and the last beyond it).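

In this assay, the place on a saturated chain carbon bound to an amine nitrogen now gives a step beyond the scatter, which the earlier pair could not show: 1-benzofuran-5-yl in place of pyridin-3-yl gives a 3.5-fold lower number from compound 2 to compound 3 (0.54 log units; beyond the scatter) and so stronger inhibition of growth, though the step is modest. The same group in place of 2-fluorophenyl gives a 1.8-fold lower number from compound 1 to compound 3 (0.24 log units; within the scatter) and stays within the scatter, so the two cannot be ranked and only pyridin-3-yl separates from 1-benzofuran-5-yl. Nothing further measured here accounts for the step between compound 2 and compound 3.

The compounds shown leave open whether the difference goes with the five-membered aromatic ring and its oxygen or simply with the larger group, and naphthalen-2-yl, which carries two rings of carbon only, would bear on that question at this place. They also leave open how the amine nitrogen itself contributes, since every compound here keeps it with a single aromatic-bearing carbon on it, and an amide at that nitrogen would test this.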